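The compounds below may be only part of what the source reports. "The series", "measured", "known", "first", "only" and "open" are said of these compounds alone.

Series notes, step from compound 2 to compound 3.

Among the compounds with values here, compound 2 `CN(C)C(=O)c1cccnc1NCCCN1CCN(c2ccccc2OCC(F)(F)F)CC1` carries the highest of the two numbers so far in a functional assay on aorta for antagonist activity at Alpha-1D adrenergic receptor (Rattus norvegicus) (a lower number here means tighter binding, a higher number weaker binding), giving 15.9 nM. Its nearest neighbour is compound 1 `CCOc1ccccc1N1CCN(CCCNc2ncccc2C(=O)N(C)C)CC1`, which in this assay gives 7.94 nM; the measured step between them, a 2.0-fold higher number from compound 1 to compound 2 (0.30 log units; within the scatter), lies within the scatter, so the two compounds are not distinguished.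

Compound 3 `CN(C)C(=O)c1cccnc1NCCCN1CCN(c2ccccc2-c2ncco2)CC1` is the next member. Relative to compound 2 the change is 1,3-oxazol-2-yl in place of 2,2,2-trifluoroethoxy on an aromatic carbon. Within the data shown here, the single measured step, a 2.0-fold higher number from compound 1 to compound 2 (0.30 log units; within the scatter), concerns a change on the saturated chain carbon bound to the oxygen at the same position and was within the scatter. Among the measured compounds shown here, no measured pair shows the group on that aromatic carbon exchanged for a ring, so the present change has no direct precedent in the numbers. With only a within-scatter step to lean on, compound 3 is expected to stay near the range of the two measured compounds in this assay, with the uncertainty widened for the untested nature of the change; the step expected is a 1.0-fold higher number from compound 2 to compound 3 (0.00 log units; within the scatter). Compound 3 is therefore estimated at 16 nM, within 4 nM to 63 nM.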

Compound 3, dissociation constant: 25.1 nM
Estimate against measurement, compound 3: 1.6-fold (0.20 log units) below; the range from low to high includes it.
By their numbers in this assay, from the lowest: compounds 1, 2 and 3 (each within the scatter of the next, the first and the last beyond it).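

Within the data shown here, at this aromatic carbon, ortho to a large group, a ring now stands for the first time, and in this assay the exchange of 2,2,2-trifluoroethoxy for 1,3-oxazol-2-yl gives a 1.6-fold higher number from compound 2 to compound 3 (0.20 log units; within the scatter), so this pair is not distinguished and the open chain with its three fluorines can give way to a five-membered aromatic ring without a separable shift. Among these compounds, measured against ethoxy, the same ring gives a 3.2-fold higher number from compound 1 to compound 3 (0.50 log units; beyond the scatter), a modest step and the first to lie beyond the scatter, which makes ethoxy and 1,3-oxazol-2-yl the only two groups at this position that the numbers separate, with compound 2 not distinguished from either. No measurement offered here accounts for this difference.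

The compounds shown leave open whether the modest step belongs to 1,3-oxazol-2-yl alone or would also appear with a phenyl ring, a saturated morpholine ring or a simple amine on the same aromatic carbon. From the compounds shown here alone, it also remains open whether the step would keep its size with a carboxylic acid in place of the dimethylamide on the shared core.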